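This account rests on a few compounds, and the source may have more. Where it says the series, first, only, none or still open, it means among the compounds named here.

Of the compounds shown here, three have been measured in a functional assay on the whole organism with Rattus norvegicus as the target, at a dose of 25 mg/kg by the intravenous route; a higher number here means that more compound is needed for the effect, a lower number that less compound is needed. Compound 1 `N#Cc1ccc(C(=O)Nc2ccc(-c3nn[nH]n3)cc2)cc1` gives 2.4 mg/kg, compound 2 `O=C(O)c1ccc(NC(=O)c2ccc(C(=O)O)cc2)cc1` gives 25.4 mg/kg, and compound 3 `CCCCc1ccc(C(=O)Nc2cc(C(=O)O)cc(C(=O)O)c2)cc1` gives 12.3 mg/kg. Compound 3 therefore stands in the middle, with a lower number than compound 2 and a higher one than compound 1, and both gaps lie beyond the usual scatter.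

The next compound, compound 4 `O=C(O)c1cc(NC(=O)c2ccc(-c3nn[nH]n3)cc2)cc(C(=O)O)c1`, differs from compound 3 in one group: 2H-tetrazol-5-yl in place of butyl on an aromatic carbon. In words, 2H-tetrazol-5-yl stands in place of butyl on an aromatic carbon. Within the data shown here, no two measured compounds differ in only one place, so nothing measured shows the size of this change directly. Among the measured compounds shown here, the one guide is compound 1, which also carries 2H-tetrazol-5-yl and gives 2.4 mg/kg, although it differs from compound 4 elsewhere as well. A modest fall, slightly beyond the scatter, is expected, and the estimated change is a 2.5-fold lower number from compound 3 to compound 4 (0.39 log units; beyond the scatter). For compound 4 the estimated value is 5 mg/kg, with an expected range from 1.5 mg/kg to 17 mg/kg.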

Compound 4, dose for 50% inhibition: 1.2 mg/kg
Compound 4: middle estimate off by 4.2-fold (0.62 log units), on the high side, and the stated range ends above it.
By their numbers in this assay, from the lowest: compounds 4 and 1 (each within the scatter of the next); then compound 3; then compound 2.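

In this assay, among these compounds, 2H-tetrazol-5-yl in place of butyl on this aromatic carbon gives a 10-fold lower number from compound 3 to compound 4 (1.01 log units; beyond the scatter) and is the first change in one place that can be read. The large step shows that the group at this position, para to a large group, can strongly alter the dose needed, and that this exchange lowers it. Nothing available explains why this exchange has such an effect.

As far as these compounds go, only butyl and 2H-tetrazol-5-yl are compared at this position, so it remains open how an amine, a methoxy group or a longer chain would behave there. From the compounds shown here alone, it is also open whether the same exchange would give a step of similar size on the core of compound 1 or compound 2.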